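Cytotoxicity of a Quinone Series: Sulfanyl Substituent Variation

The source may report more compounds than this note shows. Statements on the series, on what has been measured and on what is new or still open speak of the compounds shown alone.

Compound 1 `CC1=CCC[C@H]2[C@](C)(CC3=CC(=O)C=C(Sc4ccccc4)C3=O)[C@@H](C)CC[C@]12C`: "not determined" (no result reported) in an ADME assay on PBMC cells (Homo sapiens) for cytotoxicity, read by MTT assay; a higher number here means a weaker inhibitor, a lower number a stronger inhibitor
Compound 2 `COC1=CC(=O)C=C(C[C@]2(C)[C@@H](C)CC[C@]3(C)C(C)=CCC[C@@H]23)C1=O`: 5900 nM
Compound 3 `CCCSC1=CC(=O)C(C[C@]2(C)[C@@H](C)CC[C@]3(C)C(C)=CCC[C@@H]23)=CC1=O`: "not determined" (no result reported)

Within the data shown here, compound 2 is the only member of this set with a measured value; in this assay compound 2 gives 5900 nM. Compound 3 gives "not determined" (no result reported) in this assay, and compound 1 gives "not determined" (no result reported), so the propylsulfanyl-bearing quinone has no measured position of its own. Compound 4 `CC1=CCC[C@H]2[C@](C)(CC3=CC(=O)C(SC(C)(C)C)=CC3=O)[C@@H](C)CC[C@]12C` differs from compound 3 by tert-butyl in place of propyl on a sulfur. Among the measured compounds shown here, with no measured step between any two compounds here, the size of this step in this assay cannot be read from the data; nothing beyond the scatter is expected in either direction. For the measured compounds named here, compound 4 is estimated at 5000 nM, within a range from 1500 nM to 20000 nM, resting only on the single value of compound 2.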

Compound 4, half-maximal inhibitory concentration: 21700 nM
Estimate against measurement, compound 4: 4.3-fold (0.64 log units) below; measured number above the stated range.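

Among these compounds, compound 3 has no single number in this assay, and no step to compound 4 can be read from it. Going by these compounds, what replacing propyl with tert-butyl on the sulfur does to this read-out stays open. No further evidence bears on this result.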